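Amine substituent swap at the tolerability ceiling

A few compounds are considered here, and "the series" means these few. Any claim that something is new, unique, unknown or untested is made for them only; others in the source may bear on it.

Compound 1 `Cc1ccc2[nH]c(=O)c(CN(Cc3ccc(OCCO)cc3)Cc3ccc(C(C)(C)C)cc3)cc2c1` gives > 5000 nM in a toxicity assay on MDCK cells (Canis lupus familiaris) for cytotoxicity, read by crystal violet staining, with a stated time of 48 h; a higher number here means that more compound is tolerated, a lower number that less compound is tolerated.
Compound 2 `Cc1ccc2[nH]c(=O)c(CN(Cc3ccc(SC(F)F)cc3)Cc3ccc(C(C)(C)C)cc3)cc2c1` gives > 5000 nM in this assay, a limit of the assay.

Compound 1 also sits at a limit, (the limit of > 5000 nM in this assay, at which 2 of the 2 values shown sit). The step that the two limits leave unreadable from compound 1 to compound 2 is therefore not readable. Compound 3 `Cc1ccc2[nH]c(=O)c(CN(Cc3ccc(C(C)(C)C)cc3)[C@H](CO)c3ccccc3)cc2c1` differs from compound 2 by 2-hydroxy-1-phenylethyl in place of 4-((difluoromethyl)sulfanyl)benzyl on an amine nitrogen. For the measured compounds named here, no measured step resolves a change of this kind, so no shift beyond the scatter is anticipated. Compound 3 is expected to give 8000 nM, between 3000 nM and 30000 nM. The expected step is a step that the limit leaves unreadable from compound 2 to compound 3.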

Compound 3, half-maximal cytotoxic concentration: > 10000 nM
Compound 3: a limit, no number; the forecaster's own chance of this, stated with the estimate: 80%; at least 1.2-fold (0.09 log units) between middle value and limit.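

For the compounds shown here, compound 1, compound 2 and compound 3 all stand at limits in this assay, so no step among them can be read. The compounds shown leave open whether any of these swaps on the amine nitrogen changes tolerance at all.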